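The compounds below may be only part of what the source reports. "The series", "measured", "known", "first", "only" and "open" are said of these compounds alone.

Compound 1 `CO[C@@H]1[C@@H](OC)[C@H](c2ccccc2)O[C@@H]2CO[C@@H](c3ccco3)O[C@@H]12`: in a functional assay on HEL cells (Homo sapiens) for cytotoxicity (a lower number here means that less compound is tolerated, a higher number that more compound is tolerated), compound 1 gives "not determined" (no result reported). Compound 2 `CO[C@@H]1[C@@H](OC)[C@H](c2ccccc2)O[C@@H]2CO[C@@H](c3ccc(Cl)cc3)O[C@@H]12`: in this assay compound 2 gives > 50 ug/mL, a limit of the assay rather than a number.

Compound 1 thus stands on no number of its own in this assay. The further value shown is the limit of > 50 ug/mL in this assay, at which 1 of the 2 values shown sits, and it belongs to compound 2. Compound 3 `CO[C@@H]1[C@@H](OC)[C@H](c2ccccc2)O[C@@H]2CO[C@@H](c3ccc4ccccc4c3)O[C@@H]12` differs from compound 1 by naphthalen-2-yl in place of furan-2-yl on a saturated ring carbon. Within the data shown here, with no measured step to lean on, any step in this assay is expected to stay within the usual scatter, in neither direction. Compound 3 is expected to give about 50 ug/mL, within 20 ug/mL to 100 ug/mL.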

Compound 3, half-maximal cytotoxic concentration: > 50 ug/mL
Compound 3 ended at the assay's limit; the forecaster's own chance of this, stated with the estimate: 65%; the middle value lies on the limit itself.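

No step can be read from compound 2 to compound 3 in this assay, since the values of both are limits: the limit of > 50 ug/mL in this assay, at which 2 of the 3 values shown sit.

The compounds shown leave open whether any group in that place on the shared core gives a true number in this assay.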